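The source may hold more compounds than are shown below. What is called first, only, known or untested is meant among the compounds shown, and "the series" means these compounds.

Measured compounds:
compound 1 `O=c1oc2ccccc2cc1C1=NN(c2ccccc2)[C@@H](c2ccc(Cl)cc2)C1`: 39.2%
compound 2 `O=c1oc2ccccc2cc1C1=NN(c2ccccc2)[C@@H](c2ccc(Cl)cc2Cl)C1`: 56.7%
compound 3 `COc1cccc([C@H]2CC(c3cc4ccccc4oc3=O)=NN2c2ccccc2)c1`: 38.3%

All three share one core and differ only in the aryl group on the saturated ring carbon. In a functional assay on the whole organism (strain albino) for inhibition, with Rattus norvegicus as the target, read by paw edema, with stated times of 1 h and 2 h, at a dose of 200 mg/kg by the oral route (on this read-out higher numbers stand for more inhibition at the one dose given (going by the name of the read-out) and lower numbers for less inhibition), compound 3 gives the lowest of the three numbers, but one of its two gaps is within the scatter, namely a number 0.9 percentage points lower from compound 1 to compound 3 (within the scatter); only the other gap stands clearly apart, namely a number 18.4 percentage points lower from compound 2 to compound 3 (beyond the scatter). Compound 4 `O=c1oc2ccccc2cc1C1=NN(c2ccccc2)[C@@H](c2ccc(O)cc2)C1` is the next compound, not yet measured. It differs from compound 3 by 4-hydroxyphenyl in place of 3-methoxyphenyl on a saturated ring carbon.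

The two steps that bear on this change are the swaps of the aryl group on the saturated ring carbon: the step of a number 0.9 percentage points lower from compound 1 to compound 3 (within the scatter), within the scatter, and the step of a number 18.4 percentage points lower from compound 2 to compound 3 (beyond the scatter), beyond it. Among the compounds with values here, a 4-hydroxyphenyl group has no measured counterpart, so no direction can be read from the data. Compound 4 is therefore expected to lie close to compound 3, with a step of a number 1.7 percentage points higher from compound 3 to compound 4 (within the scatter) in this assay. The estimate for compound 4 is 40%, with a range from 28% to 52%.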

Compound 4, a percentage reported as inhibition, in the whole organism at one dose (the size of the read-out at that dose, not a potency): 28.8%
For compound 4 the middle estimate is 11.2 percentage points above the measured one, and the stated range covers the measured number.
By their numbers in this assay, from the lowest: compounds 4, 3 and 1 (each within the scatter of the next, the first and the last beyond it); then compound 2.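

In this assay, within the data shown here, the hydroxy-for-chloro swap gives a number 10.4 percentage points lower from compound 1 to compound 4 (beyond the scatter) and is the first replacement of the 4-chlorophenyl group to end lower beyond the scatter, which the 3-methoxyphenyl group did not do. Set against 3-methoxyphenyl, the 4-hydroxyphenyl group gives a number 9.5 percentage points lower from compound 3 to compound 4 (within the scatter) so that these two groups cannot be told apart here, while against 2,4-dichlorophenyl it gives a number 27.9 percentage points lower from compound 2 to compound 4 (beyond the scatter) as the largest step among these compounds. Nothing at hand accounts for these differences at the saturated ring carbon.

Compound 3 and compound 4 differ in both the substituent and its place on the aryl ring, so the two contributions remain unseparated. A 4-methoxyphenyl or 3-hydroxyphenyl group would divide them, and a 4-aminophenyl group would show how an amine compares with the hydroxy and chloro groups.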